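This account rests on a few compounds, and the source may have more. Where it says the series, first, only, none or still open, it means among the compounds named here.

Of the compounds shown here, three have been measured in a functional assay on MDA-MB-231 cells (Homo sapiens) for inhibition, read by CCK-8 assay, with a stated time of 48 h; on this read-out lower numbers stand for stronger inhibition of growth and higher numbers for weaker inhibition of growth. Compound 1 `CCN1CCN(c2ccc(Nc3ncc(Cl)c(Nc4ccccc4C)n3)cc2)CC1` gives 3040 nM, compound 2 `CN1CCN(c2ccc(Nc3ncc(Cl)c(NCc4ccc(C(F)(F)F)cc4)n3)nc2)CC1` gives 19100 nM, and compound 3 `CN1CCN(c2ccc(Nc3ncc(Cl)c(NCc4ccco4)n3)nc2)CC1` gives 11000 nM, the second highest of the three numbers. Within the data shown here, the only step measured between close neighbours, a 1.7-fold lower number from compound 2 to compound 3 (0.24 log units; within the scatter), was a swap of rings on a saturated chain carbon bound to a nitrogen on an aromatic ring. Compound 4 `COc1cccc(Nc2nc(Nc3ccc(N4CCN(C)CC4)cn3)ncc2Cl)c1` differs from compound 3 by 3-methoxyphenyl in place of (furan-2-yl)methyl on a nitrogen on an aromatic ring, so an aromatic ring now sits on the nitrogen on an aromatic ring, as in compound 1, whose value 3040 nM is lower than that of compound 3. That kind of step has not been measured, and compound 1 differs elsewhere too, so the expectation is loose. Compound 4 is expected at 4000 nM, within 1500 nM to 12000 nM, an estimated step of a 2.8-fold lower number from compound 3 to compound 4 (0.44 log units; beyond the scatter).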

Compound 4, concentration for 50% growth inhibition: 8510 nM
Compound 4: middle estimate off by 2.1-fold (0.33 log units), on the low side, within the range that was stated.
By their numbers in this assay, from the lowest: compound 1; then compounds 4, 3 and 2 (each within the scatter of the next, the first and the last beyond it).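

Putting 3-methoxyphenyl in place of (furan-2-yl)methyl on a nitrogen on an aromatic ring gives (a 1.3-fold lower number from compound 3 to compound 4 (0.11 log units; within the scatter)), so at this position the aromatic ring attached directly to the nitrogen does not set compound 4 apart from compound 3. Among these compounds, replacing 4-(trifluoromethyl)benzyl with 3-methoxyphenyl gives (a 2.2-fold lower number from compound 2 to compound 4 (0.35 log units; beyond the scatter)), the first modest step at this position that clears the scatter. No measurement offered here explains either step.

A longer chain ending in an amine, or a carboxylic acid on the 3-methoxyphenyl ring, remains untested among the compounds shown. On these data alone, it therefore stays open whether any group at this position can shift growth inhibition by more than these small steps.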